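Varying the aryl group on the hydrazone of compound 3

This account rests on a few compounds, and the source may have more. Where it says the series, first, only, none or still open, it means among the compounds named here.

Measured compounds:
Compound 1 `COc1ccccc1-c1nnc(-c2ccc(C(=O)N/N=C/c3cccc([N+](=O)[O-])c3)cc2)o1`: in an ADME assay on THP-1 cells (Homo sapiens) for cytotoxicity (on this read-out lower numbers stand for stronger inhibition and higher numbers for weaker inhibition), compound 1 gives 119000 nM.
Compound 2 `COc1ccccc1-c1nnc(-c2ccc(C(=O)N/N=C/c3ccc(Cl)cc3Cl)cc2)o1`: compound 2 gives 78800 nM in this assay.
Compound 3 `COc1ccccc1-c1nnc(-c2ccc(C(=O)N/N=C/c3cccc(O)c3O)cc2)o1`: compound 3 gives 102000 nM in this assay.

All three compounds share the same core and differ only in the aryl group attached to the carbon that carries a double bond to nitrogen. Compound 3 holds the second highest of the three numbers. Its nearest neighbour is compound 1, with a 1.2-fold lower number from compound 1 to compound 3 (0.07 log units; within the scatter); the furthest is compound 2, with a 1.3-fold higher number from compound 2 to compound 3 (0.11 log units; within the scatter). Both steps lie within the scatter, so no order among these three can be read from the numbers.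

Compound 4 `COc1ccc(/C=N/NC(=O)c2ccc(-c3nnc(-c4ccccc4OC)o3)cc2)c(O)c1` is the next member of this series. The change from compound 3 is 2-hydroxy-4-methoxyphenyl in place of 2,3-dihydroxyphenyl on a carbon with a double bond to nitrogen. Every measured step bears on this change, since each one also exchanges the aryl group at the same place: a 1.5-fold lower number from compound 1 to compound 2 (0.18 log units; within the scatter), a 1.2-fold lower number from compound 1 to compound 3 (0.07 log units; within the scatter) and a 1.3-fold higher number from compound 2 to compound 3 (0.11 log units; within the scatter). None of them moved the number beyond the scatter, even when the substituents changed considerably. The expected step is therefore none beyond the scatter, a 1.0-fold lower number from compound 3 to compound 4 (0.01 log units; within the scatter). Compound 4 is expected to give about 100000 nM in this assay, with a range from 50000 nM to 200000 nM.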

Compound 4, half-maximal inhibitory concentration: 308000 nM
The estimate for compound 4 lay 3.1-fold (0.49 log units) below the measured number, and the stated range ends below it.
By their numbers in this assay, from the lowest: compounds 2, 3 and 1 (each within the scatter of the next); then compound 4.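

In this assay this position proves able to move the number beyond the scatter, which none of the earlier exchanges did: the 2-hydroxy-4-methoxyphenyl group gives (a 3.0-fold higher number from compound 3 to compound 4 (0.48 log units; beyond the scatter)) as well as (a 3.9-fold higher number from compound 2 to compound 4 (0.59 log units; beyond the scatter)) and (a 2.6-fold higher number from compound 1 to compound 4 (0.41 log units; beyond the scatter)). All three steps are modest, but together they set compound 4 apart as the weakest of the four, while the 3-nitrophenyl, 2,4-dichlorophenyl and 2,3-dihydroxyphenyl groups remain within the scatter of the next in the order despite their different substituents. The exchange from compound 3 to compound 4 brings in a methoxy group and leaves 1 hydrogen-bond donor where there were 2, and nothing here offers an explanation for the higher number.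

With both differences arriving in a single exchange, the compounds shown do not separate the contribution of the methoxy group from that of the lost hydroxy group. Going by these compounds, it also remains open whether an amine or a carboxylic acid on this aryl ring would move the number further up, or bring it down beyond the scatter.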